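This account rests on a few compounds, and the source may have more. Where it says the series, first, only, none or still open, it means among the compounds named here.

Measured compounds: compound 1 `CN(CCCNCc1ccc2c(c1)OCCO2)c1nc(-n2ccnc2)ns1` gives 48 nM; compound 2 `COc1ccc(CNCCCN(C)c2nc(-n3ccnc3)ns2)cc1` gives 360 nM; compound 3 `CN(CCCNCc1ccc(F)c(F)c1)c1nc(-n2ccnc2)ns1` gives > 100000 nM.

In an assay on HEK293 cells for inhibition of Nitric oxide synthase, inducible (Homo sapiens), with a stated time of 18 h (a higher number here means that more compound is needed for the effect, a lower number that less compound is needed), compound 3 stands at a limit of the assay, (the limit of > 100000 nM in this assay, at which 1 of the 3 values shown sits), so no number is known for it. Compound 4 `CN(CCCNCc1ccncc1)c1nc(-n2ccnc2)ns1` differs from compound 3 by pyridin-4-yl in place of 3,4-difluorophenyl on a saturated chain carbon bound to an amine nitrogen. Among the compounds with values here, the one measured step touching this position is an at least 270-fold higher number from compound 2 to compound 3 (2.44 log units; beyond the scatter), and compound 1 shows that a second oxygen-bearing aryl group also gives a low number. Neither step tells how a pyridin-4-yl group behaves. A return to a measurable number is expected for compound 4, but only a broad estimate can be given: 3000 nM within 200 nM to 100000 nM, which would mean an at least 33-fold lower number from compound 3 to compound 4 (1.52 log units; beyond the scatter).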

Compound 4, half-maximal effective concentration: > 100000 nM
Compound 4: a limit, no number; the forecaster's own chance of this, stated with the estimate: 30%; middle value at least 33-fold (1.52 log units) from the limit.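

The change to pyridin-4-yl from 4-methoxyphenyl on a saturated chain carbon bound to an amine nitrogen gives an at least 270-fold higher number from compound 2 to compound 4 (2.44 log units; beyond the scatter). A second group without oxygen thus joins 3,4-difluorophenyl, and among the four compounds only the oxygen-bearing aryl groups of compound 1 and compound 2 give a number. Compound 3 and compound 4 both stand at a limit, so the step between them cannot be read: the limit of > 100000 nM in this assay, at which 2 of the 4 values shown sit.

The compounds shown leave open whether a hydroxyl group on the phenyl ring would also give a number. They also leave open what a longer chain in place of the present one would do.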